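Swapping Nitro for Fluoro on an Aziridine Urea

A few compounds are considered here, and "the series" means these few. Any claim that something is new, unique, unknown or untested is made for them only; others in the source may bear on it.

Measured so far:
compound 1 `N#CC1CN1C(=O)Nc1ccc([N+](=O)[O-])cc1` gives 2600 nM
compound 2 `N#CC1CN1C(=O)NC1CCCCC1` gives 7400 nM

Both compounds were tested in a functional assay on L1210 cells (Mus musculus) for inhibition, read by MTT assay; a lower number here means a stronger inhibitor, a higher number a weaker inhibitor. Compound 1 stands at the lower of the two numbers, and the gap up to compound 2 is wider than the usual scatter of this kind of measurement, so compound 1 counts as the stronger of the pair.

Compound 3 `N#CC1CN1C(=O)Nc1ccc(F)cc1` has not yet been measured. It differs from compound 1 in a single place:

fluoro in place of nitro on an aromatic carbon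

For the measured compounds named here, no pair of measured compounds shows this same change, so there is no measured step to lean on. The step from compound 1 to compound 3 is expected to be small, toward a somewhat higher number, and may well stay within the scatter: a 1.5-fold higher number from compound 1 to compound 3 (0.19 log units; within the scatter). For compound 3 the expected result in this assay is 4000 nM, with a range from 1500 nM to 12000 nM.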

Compound 3, half-maximal inhibitory concentration: 7300 nM
Estimate against measurement, compound 3: 1.8-fold (0.26 log units) below; low and high end bracket the measured number.
By their numbers in this assay, from the lowest: compound 1; then compounds 3 and 2 (each within the scatter of the next).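

In this assay, fluoro in place of nitro on the aromatic carbon gives a 2.8-fold higher number from compound 1 to compound 3 (0.45 log units; beyond the scatter), so the group at this place on the ring does affect the result, and here nitro is the better of the two. For the compounds shown here, compound 1 and compound 2 differ in more than one place, which makes this the first step that isolates a single group. Nothing measured here explains the direction of this step.

Going by these compounds, with only nitro and fluoro compared at this place, it remains open where a group such as an amine, a methoxy or a carboxylic acid would fall relative to compound 1. Also open, on these data alone, is how much the nitrile on the shared core contributes, and whether a primary amide there would keep the activity of compound 1.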